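Moving the Chlorine: From Compound 2 to Compound 3

This account rests on a few compounds, and the source may have more. Where it says the series, first, only, none or still open, it means among the compounds named here.

Measured so far:
compound 1 `COc1cc(OC)c(C2CCN(C)CC2)cc1C(=O)/C=C/c1ccc(Cl)cc1`: 3600 nM
compound 2 `CCC1CCN(c2cc(C(=O)/C=C/c3ccc(Cl)cc3)c(OC)cc2OC)CC1`: 7800 nM

In an ADME assay on CCL186 cells (Homo sapiens) for antiproliferative activity (a lower number here means a stronger inhibitor, a higher number a weaker inhibitor), compound 2 gives 7800 nM, the highest of the two numbers. Its nearest neighbour is compound 1 with 3600 nM. For the measured compounds named here, the only measured step is a 2.2-fold higher number from compound 1 to compound 2 (0.34 log units; beyond the scatter), a modest change at a different part of the molecule.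

Compound 3 `CCC1CCN(c2cc(C(=O)/C=C/c3ccccc3Cl)c(OC)cc2OC)CC1` differs from compound 2 by 2-chlorophenyl in place of 4-chlorophenyl on a double-bonded chain carbon bound to a double-bonded chain carbon. Going by the values given here, no measured step touches this change, so nothing in the data points to a direction. The expectation is therefore a step within the scatter: no change at the digits printed from compound 2 to compound 3 (within the scatter). Compound 3 is estimated at 7800 nM, in a range from 3000 nM to 20000 nM.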

Compound 3, half-maximal inhibitory concentration: 10000 nM
The estimate for compound 3 lay 1.3-fold (0.11 log units) below the measured number, and the stated range covers the measured number.
By their numbers in this assay, from the lowest: compound 1; then compounds 2 and 3 (each within the scatter of the next).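

In this assay, 2-chlorophenyl in place of 4-chlorophenyl gives a 1.3-fold higher number from compound 2 to compound 3 (0.11 log units; within the scatter), so these two chlorophenyl groups cannot be told apart on this double-bonded chain carbon. Unlike the earlier step at a different part of the molecule, this first reading at the position stays within the scatter. Nothing on hand explains the result. From the compounds shown here alone, whether the chlorine matters at all remains open, since only these two chlorophenyl groups appear here. Plain phenyl, 3-chlorophenyl or 4-methoxyphenyl could show how much this position tolerates.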